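The source may report more compounds than this note shows. Statements on the series, on what has been measured and on what is new or still open speak of the compounds shown alone.

Among the measured compounds shown here, compound 2 `COc1ccc(C(=O)/C=C/c2cc(-c3cc(OC)c(OC)c(OC)c3)n[nH]2)cc1OC` gives 2730 nM in a functional assay on OVCAR-8 cells (Homo sapiens) for inhibition, read by sulforhodamine B assay, with a stated time of 48 h (a lower number here means a stronger inhibitor of growth, a higher number a weaker inhibitor of growth), the lower of the two numbers measured so far, while compound 1 `COc1cc(-c2cc(/C=C/C(=O)c3ccc(N)cc3)[nH]n2)cc(OC)c1OC` gives 9760 nM in this assay. For the measured compounds named here, the one measured step, a 3.6-fold lower number from compound 1 to compound 2 (0.55 log units; beyond the scatter), swapped the entire group on the carbonyl carbon. Compound 3 `COc1ccc(C(=O)/C=C/c2cc(-c3cc(OC)c(OC)c(OC)c3)n[nH]2)cc1` differs from compound 2 by hydrogen in place of methoxy on an aromatic carbon. Going by the values given here, no measured step removes a single methoxy, so that step offers only a loose guide, and a change no larger than modest in this assay is expected. Compound 3 is therefore estimated at 4000 nM, within 1500 nM to 12000 nM, an expected step of a 1.5-fold higher number from compound 2 to compound 3 (0.17 log units; within the scatter).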

Compound 3, concentration for total growth inhibition: 8260 nM
Beside the measured number, compound 3's estimate is 2.1-fold (0.31 log units) below it, and the stated range covers the measured number.
By their numbers in this assay, from the lowest: compound 2; then compounds 3 and 1 (each within the scatter of the next).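

Removing one methoxy from the 3,4-dimethoxyphenyl group of compound 2 is enough to give a 3.0-fold higher number from compound 2 to compound 3 (0.48 log units; beyond the scatter) in this assay, so this single group counts on its own. Methoxy in place of amino gives a 1.2-fold lower number from compound 1 to compound 3 (0.07 log units; within the scatter), so the earlier gain appears only with the second methoxy present. Nothing given here explains this effect. Still open, as far as these compounds go, is whether another group at this place, such as a hydroxyl, an ethoxy or a chlorine, would do what methoxy does.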